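The source may hold more compounds than are shown below. What is called first, only, known or untested is meant among the compounds shown, and "the series" means these compounds.

Measured so far: compound 1 `COc1ccc(-c2nn3c(C)cc(C)nc3c2CC(=O)N(C)Cc2ccccc2)cc1` gives 27.3 nM in an assay on HEK293T cells for displacement of a labelled ligand from Translocator protein (Homo sapiens), read by scintillation counting, with a stated time of 90 min; on this read-out lower numbers stand for stronger inhibition and higher numbers for weaker inhibition; compound 2 `CCN(Cc1ccccc1)C(=O)Cc1c(-c2ccc(OC)cc2)nn2c(C)cc(C)nc12` gives 80.6 nM.

Compound 2 stands highest of the two numbers in this assay, with compound 1 the nearer and lower one by a 3.0-fold higher number from compound 1 to compound 2 (0.47 log units; beyond the scatter). Compound 3 `COc1ccc(-c2nn3c(C)cc(C)nc3c2CC(=O)N(C)C)cc1` has not been measured; it differs from compound 2 by dimethylamino in place of benzyl(ethyl)amino on a carbonyl carbon. Going by the values given here, the only measured step, a 3.0-fold higher number from compound 1 to compound 2 (0.47 log units; beyond the scatter), touches the same amide nitrogen, and it shows that even a small change there moves the number beyond the scatter. The change from compound 2 to compound 3 is larger than that one, so a larger step is expected, and in the same direction, toward a higher number. For compound 3 the estimate in this assay is 600 nM, between 120 nM and 3000 nM. That estimate amounts to an expected step of a 7.4-fold higher number from compound 2 to compound 3 (0.87 log units; beyond the scatter).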

Compound 3, inhibition constant: 560 nM
For compound 3 the middle estimate is 1.1-fold (0.03 log units) above the measured one, within the range that was stated.
By their numbers in this assay, from the lowest: compound 1; then compound 2; then compound 3.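

In this assay, the phenyl ring of the benzyl group turns out to matter more at this amide nitrogen than the methyl on its chain did. Dimethylamino in place of benzyl(ethyl)amino on a carbonyl carbon gives a 6.9-fold higher number from compound 2 to compound 3 (0.84 log units; beyond the scatter) in this series, while hydrogen in place of phenyl on a saturated chain carbon bound to an amide-type nitrogen gives a 21-fold higher number from compound 1 to compound 3 (1.31 log units; beyond the scatter) as the largest step shown. Together the three compounds show that the number rises with both changes, and nothing here gives a reason for either step.

The compounds shown leave open whether a longer chain, such as propyl, on the amide nitrogen would keep the lower numbers of compound 1. They also leave open how an amine or a carboxylic acid on the phenyl ring would read.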